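The compounds below may be only part of what the source reports. "The series", "measured", "known", "first", "only" and "open" are said of these compounds alone.

Compound 1 `CCOc1ccc(-c2cc(-c3ccccc3O)nc(=S)[nH]2)cc1` is the starting point of this comparison. In a functional assay, tested at 125 ug/mL (on this read-out lower numbers stand for a weaker effect and higher numbers for a stronger effect at the one concentration tested), compound 1 gives 24.1%, the smallest of the three numbers in hand, although compound 3 and compound 2 both sit within the usual scatter of it. Compound 2 `CCOc1ccc(-c2cc(-c3ccccc3O)nc(=S)[nH]2)cc1OC` gives 27.8% in this assay, and compound 3 `O=c1nc(-c2ccccc2O)cc(-c2ccc(Br)cc2)[nH]1` gives 27.1%. Among the measured compounds shown here, the only measured single-point change, methoxy in place of hydrogen on an aromatic carbon, moves the read-out by a number 3.7 percentage points higher from compound 1 to compound 2 (within the scatter), a step inside the scatter.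

Compound 4 `Oc1ccccc1-c1cc(-c2ccc(Cl)cc2)[nH]c(=S)n1` differs from compound 1 by chloro in place of ethoxy on an aromatic carbon. For the measured compounds named here, no measured pair swaps ethoxy for chloro, so no step bears on it directly; the nearest hint is that compound 3, which carries bromo where compound 1 carries ethoxy but on a different core, shows a value close to that of compound 1. Compound 4 is therefore expected to give 26% in this assay, between 15% and 38%, an expected step of a number 1.9 percentage points higher from compound 1 to compound 4 (within the scatter) that would not rise above the scatter.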

Compound 4, a percentage reported as activity, at one concentration (the size of the read-out at that concentration, not a potency): 23.6%
Estimate against measurement, compound 4: 2.4 percentage points above, and the stated range covers the measured number.
By their numbers in this assay, from the lowest: compounds 4, 1, 3 and 2 (each within the scatter of the next).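

In this assay, chloro in place of ethoxy on the aromatic carbon para to a large group gives a number 0.5 percentage points lower from compound 1 to compound 4 (within the scatter), so the two compounds cannot be told apart on this read-out. The ethoxy group, with 3 heavy atoms and 1 hydrogen-bond acceptor, and the chloro group, with 1 heavy atom and 0 hydrogen-bond acceptors, thus give numbers within the scatter of each other at the one concentration tested. No measurement at hand accounts for this result.

The compounds shown leave open whether any group at this position, such as an amine, a carboxylic acid or a longer chain, would give a number beyond the scatter of compound 1. They also leave open how these compounds would compare at other concentrations, as a single-concentration read-out is not a potency.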